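Methyl on the chloropyridinyl ring: permeability before measurement

The compounds below may be only part of what the source reports. "The series", "measured", "known", "first", "only" and "open" are said of these compounds alone.

Of the compounds shown here, two have numbers so far. Compound 1 `Cc1cc(C)cc(Oc2ccc3nc(COc4cccc(C(=O)O)c4)n(C)c3n2)c1` was run in an ADME assay for permeability, using PAMPA, with a stated time of 4 h; a lower number here means that the compound crosses the layer more slowly, a higher number that the compound crosses the layer faster; in that assay compound 1 gives 17.4 10^-6 cm/s. Compound 2 `Cn1c(COc2cccc(C(=O)O)c2)nc2ccc(Oc3ccc(Cl)cn3)cc21` is its closest relative among the measured compounds, and in this assay compound 2 gives 16.2 10^-6 cm/s. The two numbers lie within the scatter of each other, so neither compound stands apart from the other on this read-out; the two different ends on the shared core give no separation in apparent permeability.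

Compound 3 `Cc1cc(Cl)cnc1Oc1ccc2nc(COc3cccc(C(=O)O)c3)n(C)c2c1` is the next member and has not yet been measured. It differs from compound 2 in one place: methyl in place of hydrogen on an aromatic carbon. Within the data shown here, no step between measured compounds covers a change of this kind, so nothing in the data so far speaks for a shift in either direction in this assay; a step no larger than the scatter is expected. Compound 3 is therefore expected to give about 17 10^-6 cm/s, within a range from 9 10^-6 cm/s to 30 10^-6 cm/s. The step this estimate implies, a 1.0-fold higher number from compound 2 to compound 3 (0.02 log units; within the scatter), is expected to sit within the scatter.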

Compound 3, apparent permeability: 13.7 10^-6 cm/s
The estimate for compound 3 lay 1.2-fold (0.09 log units) above the measured number; low and high end bracket the measured number.
By their numbers in this assay, from the lowest: compounds 3, 2 and 1 (each within the scatter of the next).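

In this assay, among these compounds, the change from 5-chloropyridin-2-yl to 5-chloro-3-methylpyridin-2-yl gives a 1.2-fold lower number from compound 2 to compound 3 (0.07 log units; within the scatter), the first step that isolates a change in one place. This position, an aromatic carbon ortho to a large group and two atoms from the ring nitrogen, therefore takes a methyl in place of hydrogen without a step that stands clear of the scatter on this read-out, something the earlier comparison of two different ends could not show. No measurement at hand offers an explanation for the size of this step.

One methyl at one place leaves open whether a different group on this carbon, such as an amine, a methoxy group or a longer chain, would give a step beyond the scatter. Also open, on these data alone, is whether the same change made at other places, or with another group in place of the chloro group on this ring, would read the same way.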